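A few compounds are considered here, and "the series" means these few. Any claim that something is new, unique, unknown or untested is made for them only; others in the source may bear on it.

Measured in a functional assay on MDA-MB-231 cells (Homo sapiens) for cytotoxicity, read by MTT assay, with a stated time of 72 h; a lower number here means a stronger inhibitor, a higher number a weaker inhibitor:
- Compound 1 `CCN(CC)Cc1ccc2nc(NC(=O)N/N=C/c3cn(Cc4ccc(C)cc4)c4ccccc34)sc2c1`: 2010 nM
- Compound 2 `Cc1ccc(Cn2cc(/C=N/NC(=O)Nc3nc4ccc(CN5CCC(C)CC5)cc4s3)c3ccccc32)cc1`: 1140 nM
- Compound 3 `Cc1ccc(Cn2cc(/C=N/NC(=O)Nc3nc4ccc(CN(C)C)cc4s3)c3ccccc32)cc1`: 1220 nM

Compound 2 cannot be ranked against the other two, since a 1.8-fold lower number from compound 1 to compound 2 (0.25 log units; within the scatter) and a 1.1-fold higher number from compound 2 to compound 3 (0.03 log units; within the scatter) both leave it within the scatter. Compound 4 `CC1CCN(Cc2ccc3nc(NC(=O)N/N=C/c4cn(Cc5ccccc5)c5ccccc45)sc3c2)CC1` differs from compound 2 in one place (hydrogen in place of methyl on an aromatic carbon), with hydrogen in place of methyl on an aromatic carbon, so that 4-methylbenzyl becomes benzyl.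

Going by the values given here, no measured step touches this place. The steps of a 1.8-fold lower number from compound 1 to compound 2 (0.25 log units; within the scatter), a 1.6-fold lower number from compound 1 to compound 3 (0.22 log units; within the scatter) and a 1.1-fold higher number from compound 2 to compound 3 (0.03 log units; within the scatter) only exchange diethylamino, 4-methylpiperidin-1-yl and dimethylamino on a saturated chain carbon, and all stay within the scatter. The data therefore give no direction for the loss of the methyl, and no step beyond the scatter is expected in this assay. The estimate rests on compound 2 (1140 nM). The expected change is small (a 1.1-fold higher number from compound 2 to compound 4 (0.02 log units; within the scatter)). For compound 4 the expected value is 1200 nM, with an estimated range from 500 nM to 2900 nM as the likely span.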

Compound 4, half-maximal inhibitory concentration: 2850 nM
Compound 4: the middle estimate sits 2.4-fold (0.38 log units) below what was measured; low and high end bracket the measured number.
By their numbers in this assay, from the lowest: compounds 2, 3, 1 and 4 (each within the scatter of the next, the first and the last beyond it).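

In this assay, the change from 4-methylbenzyl to benzyl gives a 2.5-fold higher number from compound 2 to compound 4 (0.40 log units; beyond the scatter) and is the only step among these compounds that lies beyond the scatter. The methyl on this aromatic carbon, para to a large group, therefore registers in this assay, modestly, whereas the exchanges among diethylamino, 4-methylpiperidin-1-yl and dimethylamino on the saturated chain carbon all stayed within the scatter. No evidence available here accounts for this step.

The compounds shown compare only methyl and hydrogen at this place, so it remains open how a chlorine, a methoxy group or a longer chain such as ethyl would read there. Compound 4 also carries only 4-methylpiperidin-1-yl, which leaves open whether the same step would appear with dimethylamino or diethylamino on the chain carbon.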